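Extending the acyl chain on a shared oxazolopyridine core

The source may report more compounds than this note shows. Statements on the series, on what has been measured and on what is new or still open speak of the compounds shown alone.

Measured compounds:
Compound 1, `CCCCCC(=O)c1nc2ncccc2o1`, > 10000 nM
Compound 2, `CCCCCCCC(=O)c1nc2ncccc2o1`, 631 nM
Compound 3, `CCCCCCCCCC(=O)c1nc2ncccc2o1`, 74.1 nM

All three compounds share one core and differ only in the length of the saturated chain on the carbonyl. In an assay on HEK-293T cells for inhibition of diacylglycerol lipase-alpha (Homo sapiens), read by colorimetric assay (on this read-out lower numbers stand for stronger inhibition and higher numbers for weaker inhibition), compound 1 gives only a limit of the assay, > 10000 nM, at which one of the three values sits (the limit of > 10000 nM in this assay, at which 1 of the 3 values shown sits). Compound 2 gives 631 nM in this assay. Compound 3 gives 74.1 nM and stands lowest among the numbers shown, with compound 2 as its nearest neighbour.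

The steps measured so far all run in one direction. Lengthening the chain gave an at least 15-fold lower number from compound 1 to compound 2 (1.19 log units; beyond the scatter), and the further step gave an 8.5-fold lower number from compound 2 to compound 3 (0.93 log units; beyond the scatter); across both, an at least 130-fold lower number from compound 1 to compound 3 (2.13 log units; beyond the scatter). The second step was smaller than the first.

Compound 4, `CCCCCCCCCCCC(=O)c1nc2ncccc2o1`, continues this series: ethyl in place of hydrogen on a saturated chain carbon, nine bonds along the chain from a carbonyl carbon. The two steps that bear on it, from compound 1 to compound 2 and from compound 2 to compound 3, both lowered the number, the second by less. A further lowering is therefore expected, likely smaller again, so that the step from compound 3 to compound 4 is estimated at a 3.4-fold lower number from compound 3 to compound 4 (0.53 log units; beyond the scatter). Compound 4 is thus expected to give about 22 nM in this assay, within a range from 6 nM to 80 nM.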

Compound 4, half-maximal inhibitory concentration: 30.9 nM
For compound 4 the middle estimate is 1.4-fold (0.15 log units) below the measured one; the measured number falls inside the stated range.
By their numbers in this assay, from the lowest: compound 4; then compound 3; then compound 2. At a limit, above all of these: compound 1.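

In this assay, ethyl in place of hydrogen on a saturated chain carbon, nine bonds along the chain from a carbonyl carbon, still lowered the number, a 2.4-fold lower number from compound 3 to compound 4 (0.38 log units; beyond the scatter), so the trend reaches this position, but the same change counted for much less here than at five bonds along the chain: the same change on two cores in this assay, an at least 15-fold lower number (1.19 log units; beyond the scatter) from compound 1 to compound 2 and a 2.4-fold lower number (0.38 log units; beyond the scatter) from compound 3 to compound 4, at least 6.6-fold (0.82 log units) apart, beyond the scatter of two such steps Butyl in place of hydrogen at seven bonds along the chain gave a 20-fold lower number from compound 2 to compound 4 (1.31 log units; beyond the scatter), again less than the same change at five bonds along the chain: the same change on two cores in this assay, an at least 130-fold lower number (2.13 log units; beyond the scatter) from compound 1 to compound 3 and a 20-fold lower number (1.31 log units; beyond the scatter) from compound 2 to compound 4, at least 6.6-fold (0.82 log units) apart, beyond the scatter of two such steps Over the whole series the lowering comes to an at least 320-fold lower number from compound 1 to compound 4 (2.51 log units; beyond the scatter), a step that starts from a limit of the assay: the limit of > 10000 nM in this assay, at which 1 of the 4 values shown sits.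

From the compounds shown here alone, whether a longer chain than that of compound 4 would lower the number further or reverse the trend remains open. Also open, going by these compounds, is how a carboxylic acid or an amine at the end of the chain would read in this assay.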